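Aryloxy variation on a piperidinyl thymine series: cytotoxicity notes

The source may hold more compounds than are shown below. What is called first, only, known or untested is meant among the compounds shown, and "the series" means these compounds.

The series shares one core and varies the aryl group on the oxygen on the aromatic ring. Compound 1 is `Cc1cn(C2CCN(Cc3cccc(Oc4cc(F)cc(F)c4)c3)CC2)c(=O)[nH]c1=O`, compound 2 is `Cc1cn(C2CCN(Cc3cccc(Oc4ccc(F)c(F)c4)c3)CC2)c(=O)[nH]c1=O` and compound 3 is `Cc1cn(C2CCN(Cc3cccc(Oc4cccnc4)c3)CC2)c(=O)[nH]c1=O`. In an ADME assay on MRC5 cells (Homo sapiens) for cytotoxicity, read by fluorescence and resazurin assay, with a stated time of 3 days (on this read-out higher numbers stand for weaker inhibition and lower numbers for stronger inhibition), compound 1 gives > 64000 nM, which is a limit of the assay and not a number. In this assay compound 2 gives > 64000 nM, again a limit. Compound 3 gives > 64000 nM in this assay, also a limit, so compound 3 stands where every value shown stands, at the same limit as the other two. The steps a step that the two limits leave unreadable from compound 1 to compound 2, a step that the two limits leave unreadable from compound 1 to compound 3 and a step that the two limits leave unreadable from compound 2 to compound 3 bear on the present question, and none of them has a readable size, because of the limit of > 64000 nM in this assay, at which 3 of the 3 values shown sit.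

Compound 4 is `Cc1cn(C2CCN(Cc3cccc(Oc4cc(Cl)cc(Cl)c4)c3)CC2)c(=O)[nH]c1=O`, not yet measured, and it differs from compound 3 as follows: 3,5-dichlorophenyl in place of pyridin-3-yl on an oxygen on an aromatic ring. The three measured steps on the same oxygen all ended at the limit, so no direction or size can be read from them; the expected step for compound 4 is a step that the limit leaves unreadable from compound 3 to compound 4, that is, none beyond the scatter, with the value most likely reported again as a limit. The estimate for compound 4 in this assay is 80000 nM, within a range from 30000 nM to 250000 nM.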

Compound 4, half-maximal inhibitory concentration: 6730 nM
Beside the measured number, compound 4's estimate is 12-fold (1.08 log units) above it, outside the stated range (below it).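

On the oxygen on an aromatic ring, 3,5-dichlorophenyl is the only group shown that gives a reading clear of the limit in this assay, with an at least 9.5-fold lower number from compound 3 to compound 4 (0.97 log units; beyond the scatter). The same group in place of 3,4-difluorophenyl gives an at least 9.5-fold lower number from compound 2 to compound 4 (0.97 log units; beyond the scatter), and in place of 3,5-difluorophenyl it gives an at least 9.5-fold lower number from compound 1 to compound 4 (0.97 log units; beyond the scatter), the last pair being a swap of the two fluorines for two chlorines under the same numbering in the group's name. This position therefore does respond to the aryl group in this read-out, all three new steps pointing to a lower number, whereas the steps among compound 1, compound 2 and compound 3 cannot be read because of the shared limit: the limit of > 64000 nM in this assay, at which 3 of the 4 values shown sit.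

The compounds shown leave open whether a single chlorine, as in 3-chlorophenyl, or two carbon groups, as in 3,5-dimethylphenyl, would also bring the number down from the limit. They also leave open whether 3,5-dichlorophenyl would give a similar step with an amine or a carboxylic acid added elsewhere on the shared core.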